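Benzyl on the ring amine: compound 3 to compound 4

The source may hold more compounds than are shown below. What is called first, only, known or untested is meant among the compounds shown, and "the series" means these compounds.

Working notes on a small set of pyridinone-bearing amines measured in an assay on HEK293 cells for displacement of a labelled ligand from Neuronal acetylcholine receptor; alpha2/beta2 (Rattus norvegicus), tested at 10 uM; on this read-out lower numbers stand for stronger inhibition and higher numbers for weaker inhibition. Compound 1 `CN1CCCC(Cn2ccccc2=O)C1` gives 19000 nM in this assay. Compound 2 `O=c1ccccn1CC1CCCN(Cc2ccccc2)C1` gives 100000 nM. Compound 3 `O=c1ccccn1CC1CCNCC1` gives 3600 nM, the lowest number of the three; its gap to compound 1 and its gap to compound 2 are both beyond the scatter, so compound 3 stands as the most potent of the measured compounds.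

Within the data shown here, the one measured step that bears on the next compound is a 5.3-fold higher number from compound 1 to compound 2 (0.72 log units; beyond the scatter), a modest weakening on adding an aromatic ring at the carbon bound to the ring amine nitrogen.

Compound 4 `O=c1ccccn1CC1CCN(Cc2ccccc2)CC1` differs from compound 3 by benzyl in place of hydrogen on an amine nitrogen in a ring. The change resembles the step from compound 1 to compound 2, and the same direction is expected here: a weakening beyond the scatter, of about the same size, is estimated as a 5.0-fold higher number from compound 3 to compound 4 (0.70 log units; beyond the scatter). Compound 4 is therefore expected to give 18000 nM in this assay, with a plausible range from 6000 nM to 60000 nM. Whether the benzyl group placed directly on the nitrogen behaves like the benzyl of compound 2 remains to be seen from the measurement.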

Compound 4, inhibition constant: 26000 nM
For compound 4 the middle estimate is 1.4-fold (0.16 log units) below the measured one, and the stated range covers the measured number.
By their numbers in this assay, from the lowest: compound 3; then compounds 1 and 4 (each within the scatter of the next); then compound 2.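

In this assay, benzyl in place of hydrogen on the amine nitrogen of the six-membered non-aromatic ring gives a 7.2-fold higher number from compound 3 to compound 4 (0.86 log units; beyond the scatter), so this position now has a direct reading against its unsubstituted form, with hydrogen on the nitrogen giving the lower number. The earlier step, a 5.3-fold higher number from compound 1 to compound 2 (0.72 log units; beyond the scatter), started from a compound that already carried a carbon on the ring amine, and the new step runs in the same direction, towards weaker inhibition, so neither of the two steps on a ring amine nitrogen goes against this trend. No supporting measurement is available to explain why benzyl raises the number at this position.

A single group on the nitrogen of this ring cannot separate the effect of the aromatic ring from that of simply filling the position, and methyl, ethyl or a longer chain on the same nitrogen would show whether the rise follows from any substituent or from benzyl in particular. Also open, going by these compounds, is whether a benzyl carrying a fluorine or a methoxy group on its ring, or a phenethyl group, would shift the number at this position.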